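Enantiomer of compound 1: solubility expectation

The source may hold more compounds than are shown below. What is called first, only, known or untested is meant among the compounds shown, and "the series" means these compounds.

Compound 1 `O=S(=O)(Nc1nccs1)c1ccc2c(c1)OCC[C@H]2c1ccc(C(F)(F)F)cc1-n1ccnn1` stands highest of the two measured compounds; in a physicochemical assay for solubility (a lower number here means a less soluble compound, a higher number a more soluble compound), compound 1 gives 154000 nM. Its nearest neighbour is compound 2 `Cn1nccc1-c1cc(C(F)(F)F)ccc1[C@@H]1CCOc2cc(S(=O)(=O)Nc3nccs3)ccc21`, and in this assay compound 2 gives 65000 nM. Going by the values given here, the only measured step, a 2.4-fold lower number from compound 1 to compound 2 (0.37 log units; beyond the scatter), exchanges one aromatic substituent for another. Compound 3 `O=S(=O)(Nc1nccs1)c1ccc2c(c1)OCC[C@@H]2c1ccc(C(F)(F)F)cc1-n1ccnn1` differs from compound 1 as follows: the two compounds have the same atoms and bonds and differ only in configuration as drawn: 1 of 1 stereo elements differ; a stereocentre at a saturated ring carbon is drawn S in compound 1 and R in compound 3. Among the compounds with values here, no measured step concerns a change of configuration alone, so the step to compound 2 does not bear on this one. The expected step is no change at the digits printed from compound 1 to compound 3 (within the scatter), that is, none beyond the scatter. Compound 3 is estimated at 154000 nM, with a range of 80000 nM to 300000 nM.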

Compound 3, solubility: 171000 nM
Beside the measured number, compound 3's estimate is 1.1-fold (0.05 log units) below it; the measured number falls inside the stated range.
By their numbers in this assay, from the lowest: compound 2; then compounds 1 and 3 (each within the scatter of the next).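

In this assay, going by these compounds alone, the series now shows a 1.1-fold higher number from compound 1 to compound 3 (0.05 log units; within the scatter) for the stereocentre at a saturated ring carbon, the first measured step at this position, as the earlier step changed only an aromatic substituent. Drawn S or R, this centre gives two numbers within the scatter of each other, with the 1H-1,2,3-triazol-1-yl group in place. This reading rests on a single pair, and the only difference within it is stated here: the fact that compounds 1 and 3 differ only in the configuration as drawn.

From the compounds shown here alone, whether inverting the centre is equally silent with the 1-methyl-1H-pyrazol-5-yl group remains open. So does the outcome with a carboxylic acid or an amine at that aromatic carbon.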